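Ethoxy for ethyl on a weakly active carboxy compound

A few compounds are considered here, and "the series" means these few. Any claim that something is new, unique, unknown or untested is made for them only; others in the source may bear on it.

Values in a functional assay on A-375 cells (Homo sapiens) for antiproliferative activity, read by MTT assay, with a stated time of 24 h (on this read-out higher numbers stand for weaker inhibition and lower numbers for stronger inhibition), for the measured compounds:
Compound 1 `CCc1ccc2nc(C(=O)Nc3c(F)cc(-c4cccc(F)c4)cc3F)c(C)c(O)c2c1` gives 8130 nM as its value
Compound 2 `CCOc1ccc2nc(C(=O)Nc3c(F)cc(-c4cccc(F)c4)cc3F)c(C)c(O)c2c1` gives > 100000 nM as a limit, not a number
Compound 3 `CCc1ccc2nc(C(=O)Nc3c(F)cc(-c4cccc(F)c4)cc3F)c(C)c(C(=O)O)c2c1` gives 57800 nM as its value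

For the measured compounds named here, of the two true numbers here, the one for compound 3 is the higher, which means weaker inhibition. Carboxy in place of hydroxy gave a 7.1-fold higher number from compound 1 to compound 3 (0.85 log units; beyond the scatter) and that lower starting number is the nearest one. Compound 2 stands at > 100000 nM in this assay and that is a limit.

Compound 4 `CCOc1ccc2nc(C(=O)Nc3c(F)cc(-c4cccc(F)c4)cc3F)c(C)c(C(=O)O)c2c1` keeps the carboxy of compound 3 and changes one group: ethoxy in place of ethyl on an aromatic carbon with the rest untouched. Going by the values given here, one measured step bears directly, so a higher number, meaning weaker inhibition, is expected in this assay for this swap. With hydroxy instead of carboxy, the same swap gave an at least 12-fold higher number from compound 1 to compound 2 (1.08 log units; beyond the scatter) which is a large step. That is a single pair, and the swap has not been measured with carboxy present, so a smaller rise is assumed here. The expected change is a 2.6-fold higher number from compound 3 to compound 4 (0.41 log units; beyond the scatter) by this estimate. For compound 4 the estimated value is 150000 nM with an expected range from 60000 nM to 400000 nM and only a limit may be expected.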

Compound 4, half-maximal inhibitory concentration: 14900 nM
Beside the measured number, compound 4's estimate is 10-fold (1.00 log units) above it, and the stated range ends above it.
By their numbers in this assay, from the lowest: compounds 1 and 4 (each within the scatter of the next); then compound 3. At a limit, above all of these: compound 2.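

In this assay, ethoxy in place of ethyl at this position has no single fixed effect: with carboxy on the core, the swap gives a 3.9-fold lower number from compound 3 to compound 4 (0.59 log units; beyond the scatter), whereas with hydroxy on the core it went the opposite way: the same change on two cores in this assay, an at least 12-fold higher number (1.08 log units; beyond the scatter) from compound 1 to compound 2 and a 3.9-fold lower number (0.59 log units; beyond the scatter) from compound 3 to compound 4, at least 47-fold (1.67 log units) apart, beyond the scatter of two such steps

Carboxy in place of hydroxy also changes direction, giving an at least 6.7-fold lower number from compound 2 to compound 4 (0.82 log units; beyond the scatter) with ethoxy on the core, whereas with ethyl on the core the number rose: the same change on two cores in this assay, a 7.1-fold higher number (0.85 log units; beyond the scatter) from compound 1 to compound 3 and an at least 6.7-fold lower number (0.82 log units; beyond the scatter) from compound 2 to compound 4, at least 47-fold (1.67 log units) apart, beyond the scatter of two such steps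

Among these four compounds, then, neither change can be scored on its own, as the direction of each depends on which group sits at the other place.

Going by these compounds, compound 2 gives > 100000 nM, which is a limit, and the true size of both steps that touch it stays open. Also open, on these data alone, is whether this reversal extends to other groups, such as methoxy or a longer chain like propyl in place of the ethoxy, or an amine in place of the carboxy.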